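Swapping an isopropyl for a halogenated phenyl

The compounds below may be only part of what the source reports. "The series", "measured", "known", "first", "only" and "open" are said of these compounds alone.

Of the compounds shown here, three sharing one core have been measured in an ADME assay on HepG2 cells (Homo sapiens) for cytotoxicity, read by luminescence, CellTiter-Glo and ATP content, with a stated time of 72 h; a lower number here means that less compound is needed, a higher number that more compound is needed for the effect. Compound 1 `COc1ccc(F)cc1CNCCCNc1ccnc2cc(CCC(C)C)ccc12` gives 890 nM; compound 2 `COc1ccc(F)cc1CNCCCNc1ccnc2cc(CCc3ccccc3)ccc12` gives 4240 nM; compound 3 `COc1ccc(F)cc1CNCCCNc1ccnc2cc(CC(C)C)ccc12` gives 2900 nM. Compound 3 thus stands second highest of the three: it cannot be separated from compound 2, because a 1.5-fold lower number from compound 2 to compound 3 (0.16 log units; within the scatter), but it needs clearly more compound than compound 1, because a 3.3-fold higher number from compound 1 to compound 3 (0.51 log units; beyond the scatter). Compound 4 `COc1ccc(F)cc1CNCCCNc1ccnc2cc(Cc3ccc(F)cc3Cl)ccc12` follows from compound 3 by one change: 2-chloro-4-fluorophenyl in place of isopropyl on a saturated chain carbon bound to an aromatic carbon. Among the compounds with values here, the nearest precedent is the benzyl-for-isopropyl contrast, where a 1.5-fold lower number from compound 2 to compound 3 (0.16 log units; within the scatter), and the other aryl-bearing step, a 4.8-fold higher number from compound 1 to compound 2 (0.68 log units; beyond the scatter), was only modest. A small rise or none beyond the scatter is therefore expected. For compound 4 the estimated step is a 1.6-fold higher number from compound 3 to compound 4 (0.19 log units; within the scatter). Compound 4 is expected to give about 4500 nM, within 2000 nM to 10000 nM.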

Compound 4, half-maximal effective concentration: 2460 nM
Compound 4: the middle estimate sits 1.8-fold (0.26 log units) above what was measured; the range from low to high includes it.
By their numbers in this assay, from the lowest: compound 1; then compounds 4, 3 and 2 (each within the scatter of the next).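

In this assay, the saturated chain carbon bound to an aromatic carbon now accepts a halogenated aromatic ring without a readable shift from either isopropyl (a 1.2-fold lower number from compound 3 to compound 4 (0.07 log units; within the scatter)) or benzyl (a 1.7-fold lower number from compound 2 to compound 4 (0.24 log units; within the scatter)). Only the isobutyl compound stays apart (a 2.8-fold higher number from compound 1 to compound 4 (0.44 log units; beyond the scatter)), so compound 1 remains alone at the low end of these numbers. No measured evidence bears on what lies behind this. From the compounds shown here alone, it remains open whether chlorine and fluorine each matter on the ring, and whether an amine or a carboxylic acid here would separate from these groups.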